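Removing the amino group from compound 3

This account rests on a few compounds, and the source may have more. Where it says the series, first, only, none or still open, it means among the compounds named here.

Measured so far:
compound 1 `COc1ncnc2c1c(-c1ccsc1)cn2[C@@H]1O[C@H](CO)[C@@H](O)[C@H]1O` — 120 nM
compound 2 `C#Cc1cn([C@@H]2O[C@H](CO)[C@@H](O)[C@H]2O)c2ncnc(NC)c12` — > 20000 nM
compound 3 `C#Cc1cn([C@@H]2O[C@H](CO)[C@@H](O)[C@H]2O)c2nc(N)nc(OC)c12` — > 20000 nM

For the measured compounds named here, in a functional assay on HCT-116 cells (Homo sapiens), read by MTT assay, with a stated time of 72 h (a higher number here means a weaker inhibitor, a lower number a stronger inhibitor), compound 1 gives 120 nM, the only numerical value among the three. For compound 2 the result is a limit, > 20000 nM. For compound 3 the result is likewise a limit, > 20000 nM; compound 3 therefore stands at the limit of > 20000 nM in this assay, at which 2 of the 3 values shown sit, with no number of its own. Compound 4 `C#Cc1cn([C@@H]2O[C@H](CO)[C@@H](O)[C@H]2O)c2ncnc(OC)c12` has not been measured. It differs from compound 3 by hydrogen in place of amino on an aromatic carbon. With no measured step of this kind shown, the size of the step in this assay is open; a move toward a stronger inhibitor, beyond the scatter, is expected, estimated as an at least 6.6-fold lower number from compound 3 to compound 4 (0.82 log units; beyond the scatter). Compound 4 is expected to give about 3000 nM, within 300 nM to 20000 nM.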

Compound 4, half-maximal inhibitory concentration: 4060 nM
Estimate against measurement, compound 4: 1.4-fold (0.13 log units) below, within the range that was stated.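

Compound 2 and compound 3 each give only a limit: the limit of > 20000 nM in this assay, at which 2 of the 4 values shown sit.

Against that limit, hydrogen in place of amino on the aromatic carbon between two ring nitrogen atoms gives a measurable value in this assay, with an at least 4.9-fold lower number from compound 3 to compound 4 (0.69 log units; beyond the scatter), and methoxy in place of methylamino also does, with an at least 4.9-fold lower number from compound 2 to compound 4 (0.69 log units; beyond the scatter). Ethynyl in place of thiophen-3-yl still gives a large loss, with a 34-fold higher number from compound 1 to compound 4 (1.53 log units; beyond the scatter).

As far as these compounds go, the true size of the first two steps remains open. Also open, from the compounds shown here alone, is how a methyl group or a chlorine atom would fare on that carbon between the two ring nitrogen atoms, or a phenyl ring in place of ethynyl.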